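Swapping the bicyclic ether group of a cytotoxicity series

The source may report more compounds than this note shows. Statements on the series, on what has been measured and on what is new or still open speak of the compounds shown alone.

compound 1 `Cc1cc(=O)n(-c2cccc(F)c2)nc1C(=O)Nc1ccc(Oc2ncnc3ccsc23)cc1`: 10200 nM
compound 2 `Cc1cc(=O)n(-c2ccc(F)cc2)nc1C(=O)Nc1ccc(Oc2ncnc3ccsc23)cc1`: 2110 nM

In a functional assay on HepG2 cells (Homo sapiens) for cytotoxicity, read by MTT assay, with a stated time of 72 h (on this read-out higher numbers stand for weaker inhibition and lower numbers for stronger inhibition), compound 1 gives 10200 nM, the highest of the two numbers; the nearest, compound 2, is reached by a 4.8-fold lower number from compound 1 to compound 2 (0.68 log units; beyond the scatter). Compound 3 `Cc1cc(=O)n(-c2cccc(F)c2)nc1C(=O)Nc1ccc(Oc2ncnc3sccc23)cc1` differs from compound 1 by a group of 9 heavy atoms (6 carbon, 2 nitrogen, 1 sulfur; one five-membered aromatic ring with 1 hetero atom, one six-membered aromatic ring with 2 hetero atoms) in place of a group of 9 heavy atoms (6 carbon, 2 nitrogen, 1 sulfur; one five-membered aromatic ring with 1 hetero atom, one six-membered aromatic ring with 2 hetero atoms), on an oxygen on an aromatic ring; the two have the same atoms, joined differently. Within the data shown here, no measured step touches this group: the only step known, a 4.8-fold lower number from compound 1 to compound 2 (0.68 log units; beyond the scatter), alters another part of the molecule and offers no guide here. The expected shift is therefore none beyond the scatter, estimated as a 1.0-fold lower number from compound 1 to compound 3 (0.01 log units; within the scatter). Compound 3 is estimated at 10000 nM, with a range from 3000 nM to 35000 nM.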

Compound 3, half-maximal inhibitory concentration: 18500 nM
Beside the measured number, compound 3's estimate is 1.9-fold (0.27 log units) below it, and the stated range covers the measured number.
By their numbers in this assay, from the lowest: compound 2; then compounds 1 and 3 (each within the scatter of the next).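

Among these compounds, the first change to the group on an oxygen on an aromatic ring keeps the same atoms but joins them differently, and in this assay it gives a 1.8-fold higher number from compound 1 to compound 3 (0.26 log units; within the scatter). The measurement therefore does not separate these two arrangements, so this reconnection has no clear effect on the read-out. Nothing shown explains the small gap between the numbers. Still open, from the compounds shown here alone, is whether the 4-fluorophenyl group, seen in compound 2, would give a similar step alongside the entering group. Also open, going by these compounds, is how an amine or a carboxylic acid at this place would read.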